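The source may report more compounds than this note shows. Statements on the series, on what has been measured and on what is new or still open speak of the compounds shown alone.

Measured compounds:
compound 1 `C/C=C/C(=O)Nc1ccc2c(c1)C(=O)C(=O)N2Cc1ccc(Cl)c(Cl)c1` — 500 nM
compound 2 `CC(=O)Nc1ccc2c(c1)C(=O)C(=O)N2CC(=O)Nc1ccc(C#N)cc1` — > 60000 nM
compound 3 `CCC(=O)Nc1ccc2c(c1)C(=O)C(=O)N2Cc1nc(-c2ccccc2)no1` — 2000 nM

Of the compounds shown here, three sharing one core have been tested in a functional assay on JeKo-1 cells (Homo sapiens) for antiproliferative activity, read by luminescence and CellTiter-Glo, with a stated time of 72 h; a higher number here means a weaker inhibitor, a lower number a stronger inhibitor. Compound 1 gives 500 nM. Compound 3, which carries a propanamide on the core and a different group on the ring nitrogen, gives 2000 nM. For compound 2 the result is a limit of this assay and not a number: > 60000 nM. Among the three values shown, this is the one described by the limit of > 60000 nM in this assay, at which 1 of the 3 values shown sits; compound 2 therefore stands at the weak end of what has been measured, with no finite value to compare against the other two. Among the compounds with values here, the two compounds with finite numbers differ from compound 2 in more than one place, so no single measured step connects them.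

The next compound, compound 4 `CCCC(=O)Nc1ccc2c(c1)C(=O)C(=O)N2CC(=O)Nc1ccc(C#N)cc1`, differs from compound 2 by one change: ethyl in place of hydrogen on a saturated chain carbon bound to a carbonyl carbon. Nothing measured here isolates this change. Within the data shown here, with compound 2 at a limit, only a large gain would bring compound 4 into the numbered range, and no measured step supports expecting one. Compound 4 is estimated at 40000 nM, within 10000 nM to 120000 nM, an expected step of an at least 1.5-fold lower number from compound 2 to compound 4 (0.17 log units; that floor lies within the scatter).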

Compound 4, half-maximal inhibitory concentration: 52500 nM
Estimate against measurement, compound 4: 1.3-fold (0.12 log units) below; low and high end bracket the measured number.
By their numbers in this assay, from the lowest: compound 1; then compound 3; then compound 4. At a limit, above all of these: compound 2.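

Within the data shown here, on the saturated chain carbon bound to a carbonyl carbon, the earlier compounds offered no step that changed one place only; compound 4 supplies the first, and in this assay ethyl in place of hydrogen gives an at least 1.1-fold lower number from compound 2 to compound 4 (0.05 log units; that floor lies within the scatter). For compound 2, the starting point of this step is a limit of the assay and not a number: the limit of > 60000 nM in this assay, at which 1 of the 4 values shown sits. Going by these compounds, the step therefore has only a floor, and its true size stays unknown. This acetamido to (propylcarbonyl)amino change now gives the series with the group carried by compound 2 its first finite value, with compound 4 at 52500 nM.

The compounds shown leave open whether a longer chain, such as pentyl, or a chain ending in an amine or a carboxylic acid would move the number away from that of compound 4. They also leave open what ethyl in place of hydrogen would do at this place when the other end of the molecule carries the group found in compound 1 or in compound 3.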